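Trifluoromethyl for methyl on a pyridyl ether core

The source may report more compounds than this note shows. Statements on the series, on what has been measured and on what is new or still open speak of the compounds shown alone.

Of the compounds shown here, three sharing one core have been measured in a functional assay for agonist activity at Free fatty acid receptor 1 (Homo sapiens), read by FLIPR, in the presence of a further agent that is not named here; on this read-out lower numbers stand for an effect already at smaller amounts and higher numbers for an effect only at larger amounts of compound. Compound 1 `O=C1NC(=O)C(Cc2ccc(Oc3ccc(C(F)(F)F)cn3)cc2)S1` gives 558 nM. Compound 2 `Cc1ccc(Oc2ccc(CC3SC(=O)NC3=O)cc2)nc1` gives 4470 nM, and compound 3 `Cc1cccnc1Oc1ccc(CC2SC(=O)NC2=O)cc1` gives 1090 nM. Compound 1 and compound 2 differ in one place: trifluoromethyl in place of methyl on an aromatic carbon This change made an 8.0-fold lower number from compound 2 to compound 1 (0.90 log units; beyond the scatter). Compound 2 and compound 3 differ only in how the same atoms are joined: 3-methylpyridin-2-yl in place of 5-methylpyridin-2-yl on an oxygen on an aromatic ring That rearrangement made a 4.1-fold lower number from compound 2 to compound 3 (0.61 log units; beyond the scatter). Compound 3 and compound 1 lie within the scatter of each other in this assay, so no order between them can be read.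

Compound 4 `O=C1NC(=O)C(Cc2ccc(Oc3ncccc3C(F)(F)F)cc2)S1` has not yet been measured. Within the data shown here, it differs from compound 3 as follows: trifluoromethyl in place of methyl on an aromatic carbon This is the same kind of change as the one from compound 2 to compound 1, but not the same: in compound 4 the entering group is ortho to a large group, whereas in compound 1 it is para to a large group; in both it sits two atoms from the ring nitrogen. Among the measured compounds shown here, only one measured pair of this kind exists, so the expectation rests on the step from compound 2 to compound 1 of an 8.0-fold lower number from compound 2 to compound 1 (0.90 log units; beyond the scatter), tempered for the different place. The step from compound 3 to compound 4 is expected to be a 3.1-fold lower number from compound 3 to compound 4 (0.49 log units; beyond the scatter). Compound 4 is estimated at 350 nM in this assay. Its expected range runs from 120 nM to 1000 nM.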

Compound 4, half-maximal effective concentration: 2290 nM
The estimate for compound 4 lay 6.5-fold (0.82 log units) below the measured number; the measured number lies above the stated range.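

Moving the same swap to a second core did not repeat its earlier result. In this assay, trifluoromethyl in place of methyl gave a 2.1-fold higher number from compound 3 to compound 4 (0.32 log units; beyond the scatter), a change in the opposite direction to the earlier step, and the two steps clearly disagree: the same change on two cores in this assay, an 8.0-fold lower number (0.90 log units; beyond the scatter) from compound 2 to compound 1 and a 2.1-fold higher number (0.32 log units; beyond the scatter) from compound 3 to compound 4, 17-fold (1.23 log units) apart, beyond the scatter of two such steps This shows that, in this series, the result of the swap on one core cannot simply be carried over to another, even when the group that leaves and the group that enters are the same. Among these compounds, it does not show why the two results part, since only two pairs are available and they differ in where the swap sits, with the trifluoromethyl of compound 4 ortho to a large group, so these compounds cannot separate the effect of that place from any other influence or yield a general rule for the series.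

The compounds shown leave open how other groups would behave at the place occupied by the trifluoromethyl in compound 4, for example a chlorine atom, a methoxy group or a nitrile. They also leave open whether an amine or a carboxylic acid there would follow the methyl or the trifluoromethyl compound in this read-out.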